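Swapping the anilide ring on a shared core

A few compounds are considered here, and "the series" means these few. Any claim that something is new, unique, unknown or untested is made for them only; others in the source may bear on it.

- Compound 1 `O=C(Nc1ccccc1)c1cc2cnc(Nc3ccc(N4CCNCC4)cn3)nc2n1C1CCCC1`: 2800 nM
- Compound 2 `COc1ccc(NC(=O)c2cc3cnc(Nc4ccc(N5CCNCC5)cn4)nc3n2C2CCCC2)c(OC)c1`: 2230 nM

Both values come from a functional assay on MIA PaCa-2 cells (Homo sapiens) for inhibition, read by MTT assay (a lower number here means a stronger inhibitor, a higher number a weaker inhibitor), and compound 2 stands level with compound 1 within the scatter. Compound 3 `O=C(Nc1ccccc1C(F)(F)F)c1cc2cnc(Nc3ccc(N4CCNCC4)cn3)nc2n1C1CCCC1` differs from compound 2 at the amide: 2-(trifluoromethyl)phenyl in place of 2,4-dimethoxyphenyl on an amide-type nitrogen. It carries 2-(trifluoromethyl)phenyl in place of 2,4-dimethoxyphenyl on an amide-type nitrogen. Among the compounds with values here, only one measured step bears on this, at the same place: a 1.3-fold lower number from compound 1 to compound 2 (0.10 log units; within the scatter). This is thin evidence, but no change beyond the scatter is expected in this assay. The expected step is a 1.1-fold higher number from compound 2 to compound 3 (0.05 log units; within the scatter). For compound 3 the estimated value is 2500 nM, with an expected range of 1200 nM to 5200 nM.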

Compound 3, half-maximal inhibitory concentration: 3160 nM
Compound 3: the middle estimate sits 1.3-fold (0.10 log units) below what was measured, and the stated range covers the measured number.
By their numbers in this assay, from the lowest: compounds 2, 1 and 3 (each within the scatter of the next).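

Putting 2-(trifluoromethyl)phenyl in place of 2,4-dimethoxyphenyl on the amide-type nitrogen gives a 1.4-fold higher number from compound 2 to compound 3 (0.15 log units; within the scatter) in this assay and trifluoromethyl in place of hydrogen on an aromatic carbon gives a 1.1-fold higher number from compound 1 to compound 3 (0.05 log units; within the scatter) in that same assay. The position thus holds a ring with no hydrogen-bond acceptors, a ring with two and a plain phenyl, all level within the scatter.

On these data alone, whether an amine or a carboxylic acid on this ring, or a longer alkyl chain in place of it, would move the number beyond the scatter stays open. Nothing available explains why these three compounds sit level.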